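Prenyl in Place of Cyclopropylmethyl on the Dibromoaryl Amidine

The compounds below may be only part of what the source reports. "The series", "measured", "known", "first", "only" and "open" are said of these compounds alone.

Compound 1 `Brc1cccc(Br)c1N(CC1CC1)C1=NCCN1` gives -1.12 in a physicochemical assay for lipophilicity (a higher number here means a more lipophilic compound, a lower number a more polar compound), the lowest of the three numbers at hand. Compound 2 `CC(C)N(C1=NCCN1)c1c(Br)cccc1Br` gives -0.82, and the step of a number 0.30 log units higher from compound 1 to compound 2 (within the scatter). Compound 3 `CC(C)CCN(C1=NCCN1)c1c(Br)cccc1Br` gives 0.16, and the step of a number 1.28 log units higher from compound 1 to compound 3 (beyond the scatter). Compound 4 `CC(C)=CCN(C1=NCCN1)c1c(Br)cccc1Br` has not yet been measured. It differs from compound 1 in one place: 2-methylprop-1-en-1-yl in place of cyclopropyl on a saturated chain carbon bound to a nitrogen on an aromatic ring. Among the compounds with values here, the step from compound 1 to compound 3 is the closest precedent, since it also replaces the cyclopropyl at the same place with a larger open chain; the step of a number 0.98 log units higher from compound 2 to compound 3 (beyond the scatter) points the same way. Compound 4 is therefore expected to lie above compound 1, with an estimated step of a number 0.82 log units higher from compound 1 to compound 4 (beyond the scatter). The estimate for compound 4 is -0.3, ranging from -0.9 to 0.3.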

Compound 4, distribution coefficient: -0.14
Beside the measured number, compound 4's estimate is 0.16 log units below it, within the range that was stated.
By their numbers in this assay, from the lowest: compounds 1 and 2 (each within the scatter of the next); then compounds 4 and 3 (each within the scatter of the next).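

In this assay, 3-methylbut-2-en-1-yl in place of cyclopropylmethyl gives a number 0.98 log units higher from compound 1 to compound 4 (beyond the scatter), and in place of isopropyl it gives a number 0.68 log units higher from compound 2 to compound 4 (beyond the scatter). The double bond itself cannot be read at this position: against the saturated isopentyl chain, the result is a number 0.30 log units lower from compound 3 to compound 4 (within the scatter). Both open chains therefore stand clear of cyclopropylmethyl and isopropyl, with or without the double bond.

Nothing at hand explains these steps. From the compounds shown here alone, whether a longer chain, or a hydroxyl group on this chain, would keep this pattern remains open.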